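Swapping an acetamidomethyl for a tetrazole on a shared core

The source may report more compounds than this note shows. Statements on the series, on what has been measured and on what is new or still open speak of the compounds shown alone.

Compound 1, `CC(=O)NCc1ccc2c(c1)nc(Cn1c(=O)n(C(C)C)c3ccccc31)n2CCC(C)C`, was tested in an ADME assay on HEp-2 cells (Homo sapiens) for cytotoxicity (on this read-out lower numbers stand for higher toxicity in this test and higher numbers for lower toxicity in this test), where compound 1 gives 178000 nM. That is the highest of the two numbers recorded, meaning the least toxic of the pair in this test. Among the measured compounds shown here, its only measured neighbour is compound 2, `COC(=O)c1cccc2c1nc(Cn1c(=O)n(C(C)C)c3ccccc31)n2CCC(C)C`, which in this assay gives 49200 nM, a lower number that lies beyond the usual scatter.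

Compound 3, `CC(C)CCn1c(Cn2c(=O)n(C(C)C)c3ccccc32)nc2cc(-c3nn[nH]n3)ccc21`, has not yet been measured in this assay. It differs from compound 1 in one place: 2H-tetrazol-5-yl in place of acetamidomethyl on an aromatic carbon. For the measured compounds named here, no pair of measured compounds shows this particular swap, so there is nothing to anchor the expected size of the step. The nearest guidance is that compound 1 sits at 178000 nM, and the expectation is a step of about a 1.2-fold lower number from compound 1 to compound 3 (0.07 log units; within the scatter), roughly no change beyond the scatter. Compound 3 is therefore estimated at 150000 nM, with a plausible range from 50000 nM to 400000 nM.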

Compound 3, half-maximal cytotoxic concentration: 2000 nM
Compound 3: middle estimate off by 75-fold (1.88 log units), on the high side, outside the stated range (below it).
By their numbers in this assay, from the lowest: compound 3; then compound 2; then compound 1.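

This position turns out to be highly sensitive in this assay: replacing acetamidomethyl with 2H-tetrazol-5-yl on this aromatic carbon gives an 89-fold lower number from compound 1 to compound 3 (1.95 log units; beyond the scatter) and so a large move towards higher toxicity in this test. The size of the step does not follow the simple counts, as the leaving and entering groups both have 5 heavy atoms, 1 hydrogen-bond donor and no net charge, while they differ in the ring and in hydrogen-bond acceptors, 1 against 3. No measurement available here accounts for why this swap has such a large effect.

Going by these compounds, it remains open whether the shift is specific to the 2H-tetrazol-5-yl ring or would also appear with another group at this position, such as a carboxylic acid or an amine. On these data alone, how the same swap would behave elsewhere on the shared core also remains unknown.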